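A few compounds are considered here, and "the series" means these few. Any claim that something is new, unique, unknown or untested is made for them only; others in the source may bear on it.

Measured in an ADME assay on microsomes from liver (Mus musculus) for metabolic stability; on this read-out lower numbers stand for slow clearance and higher numbers for fast clearance:
- compound 1 `CCS(=O)(=O)Nc1ccc(Oc2ccc(C#N)cc2)c(-c2cn(C)c(=O)c3[nH]ccc23)c1`: < 109 mL/min/kg (a limit of the assay, not a number)
- compound 2 `Cn1cc(-c2cc(NS(C)(=O)=O)ccc2OC2CCC(F)(F)CC2)c2cc[nH]c2c1=O`: 717 mL/min/kg

Compound 1 stands at the limit of < 109 mL/min/kg in this assay, at which 1 of the 2 values shown sits. Going by the values given here, compound 2 is the only compound with a number, and that number lies well on the fast-clearance side of the limit held by compound 1.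

Compound 3 `CCS(=O)(=O)Nc1ccc(OC2CCC(N(C)C)CC2)c(-c2cn(C)c(=O)c3[nH]ccc23)c1` has not yet been measured in this assay. It keeps the core of compound 1 and carries 4-(dimethylamino)cyclohexyl in place of 4-cyanophenyl on an oxygen on an aromatic ring.

Among the compounds with values here, no measured step between compounds differing in one place is available, so the expectation for this change is loosely founded. Within the data shown here, the only guide is compound 2 at 717 mL/min/kg, which suggests that fast clearance occurs. A move toward faster clearance is therefore expected, of moderate size and beyond the usual scatter. The expected change is an at least 2.2-fold higher number from compound 1 to compound 3 (0.36 log units; beyond the scatter). The estimated clearance of compound 3 is 250 mL/min/kg, with an expected range of 100 mL/min/kg to 650 mL/min/kg.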

Compound 3, clearance: 125 mL/min/kg
Compound 3: the middle estimate sits 2.0-fold (0.30 log units) above what was measured; the measured number falls inside the stated range.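

In this assay compound 1 gives < 109 mL/min/kg, which is a limit of the assay and not a number. With the core of compound 1 held fixed, compound 3 gives a true number at this position, 125 mL/min/kg, so this read-out can be reported as a number with 4-(dimethylamino)cyclohexyl on an oxygen on an aromatic ring. The change from 4-cyanophenyl to 4-(dimethylamino)cyclohexyl gives an at least 1.1-fold higher number from compound 1 to compound 3 (0.05 log units; that floor lies within the scatter), and this step is only a floor, so it cannot show whether the change moves clearance beyond the scatter, because one end of the pair rests on a limit: the limit of < 109 mL/min/kg in this assay, at which 1 of the 3 values shown sits.

From the compounds shown here alone, the true size of the step stays open, and so does how it divides between the swap of the aromatic ring for a non-aromatic one and the dimethylamino group itself. A plain cyclohexyl, or a cyclohexyl carrying a hydroxyl group or a morpholine in place of the dimethylamino group, would separate these two parts of the change on the same core.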